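Shortening and branching the amide substituent on compound 3

This account rests on a few compounds, and the source may have more. Where it says the series, first, only, none or still open, it means among the compounds named here.

Measured so far:
Compound 1, `CCCCOc1cc(C(=O)NCC)nn1-c1ccccc1`: 0%
Compound 2, `C=CCNC(=O)c1cc(OCCCC)n(-c2ccccc2)n1`: 4.4%
Compound 3, `CCCCNC(=O)c1cc(OCCCC)n(-c2ccccc2)n1`: 43.3%

In a functional assay on the whole organism (strain Wistar) for inhibition, with Rattus norvegicus as the target, read by paw edema, with stated times of 30 min and 3 h, at a dose of 100 mg/kg by the oral route (on this read-out higher numbers stand for more inhibition at the one dose given (going by the name of the read-out) and lower numbers for less inhibition), compound 3 stands highest of the three, beyond the scatter from both others. The steps of a number 43.3 percentage points higher from compound 1 to compound 3 (beyond the scatter) and a number 38.9 percentage points higher from compound 2 to compound 3 (beyond the scatter) show that a longer chain on the amide nitrogen gave a large rise, while a number 4.4 percentage points higher from compound 1 to compound 2 (within the scatter) was within the scatter. Compound 4, `CCCCOc1cc(C(=O)NC(C)C)nn1-c1ccccc1`, differs from compound 3 by isopropyl in place of butyl on an amide-type nitrogen. Since shorter groups on that nitrogen gave low numbers in compound 1 and compound 2, a fall is expected for compound 4 in this assay, though a branched group of three carbons lies between the cases seen. The expected step is a number 25.3 percentage points lower from compound 3 to compound 4 (beyond the scatter). Compound 4 is estimated at 18%, from 0% to 42%.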

Compound 4, a percentage reported as inhibition, in the whole organism at one dose (the size of the read-out at that dose, not a potency): 15.8%
Estimate against measurement, compound 4: 2.2 percentage points above, within the range that was stated.
By their numbers in this assay, from the lowest: compounds 1 and 2 (each within the scatter of the next); then compound 4; then compound 3.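

In this assay the change to isopropyl on the amide-type nitrogen gives a number 27.5 percentage points lower from compound 3 to compound 4 (beyond the scatter) and so does not keep the level seen with butyl. Isopropyl still improves on the smaller ethyl group, with a number 15.8 percentage points higher from compound 1 to compound 4 (beyond the scatter) and on allyl, with a number 11.4 percentage points higher from compound 2 to compound 4 (beyond the scatter) so this position gives graded results across these compounds rather than a simple on or off. Nothing here explains this order.

Straight propyl would help show whether branching or chain length matters more here. Going by these compounds, whether hexyl, a longer chain than butyl, would raise the number further also remains open.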